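Ethoxy on the coumarin-side ring of compound 1

The source may hold more compounds than are shown below. What is called first, only, known or untested is meant among the compounds shown, and "the series" means these compounds.

Compound 1 `COc1ccc(/C=C/c2cc(OC)cc(OC)c2/C=C/C(=O)c2cc3ccccc3oc2=O)cc1` gives 9170 nM in an assay on isolated protein for inhibition of Amine oxidase [flavin-containing] B (Homo sapiens), read by fluorescence, with a stated time of 15 min (a lower number here means a stronger inhibitor, a higher number a weaker inhibitor), the only plain number among the three results shown. Compound 2 `COc1ccc(/C=C/c2cc(OC)cc(OC)c2/C=C/C(=O)c2cc3cc(OC)ccc3oc2=O)cc1` sits at a limit of the assay, > 60000 nM. Compound 3 `COc1ccc(/C=C/c2cc(OC)cc(OC)c2/C=C/C(=O)c2cc3cc(Br)cc(OC)c3oc2=O)cc1` likewise sits at a limit, > 60000 nM. Compound 4 `CCOc1ccc2cc(C(=O)/C=C/c3c(/C=C/c4ccc(OC)cc4)cc(OC)cc3OC)c(=O)oc2c1` differs from compound 1 by ethoxy in place of hydrogen on an aromatic carbon. Among the measured compounds shown here, the one measured step that bears on it is an at least 6.5-fold higher number from compound 1 to compound 2 (0.81 log units; beyond the scatter), which points to the limit of > 60000 nM in this assay, at which 2 of the 3 values shown sit. Compound 4 is therefore expected to show a weaker result than compound 1, a step of about a 6.5-fold higher number from compound 1 to compound 4 (0.82 log units; beyond the scatter), quite possibly again only reported as a limit. The estimate for compound 4 is 60000 nM, in the range 15000 nM to 200000 nM.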

Compound 4, half-maximal inhibitory concentration: 48100 nM
Beside the measured number, compound 4's estimate is 1.2-fold (0.10 log units) above it, and the stated range covers the measured number.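

In this assay, ethoxy in place of hydrogen on this aromatic carbon gives a step of measured size: a 5.2-fold higher number from compound 1 to compound 4 (0.72 log units; beyond the scatter). Compound 4 therefore gives a plain number and shows that this substitution weakens the result while still leaving it readable. Compound 2, by contrast, is reported only as a limit of the assay, > 60000 nM.

The compounds shown leave open whether an amine or a carboxylic acid on this carbon would match compound 1. They also do not show whether a longer chain in place of ethoxy would weaken the result further.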